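The source may hold more compounds than are shown below. What is called first, only, known or untested is meant among the compounds shown, and "the series" means these compounds.

In an ADME assay on A549 cells (Homo sapiens) for cytotoxicity, read by resazurin assay, with a stated time of 48 h (on this read-out higher numbers stand for lower toxicity in this test and lower numbers for higher toxicity in this test), compound 1 (`CCCCCCCCC(C)Nc1ccc(NC(=O)c2cc(Cl)ccc2O)c(Cl)c1`) gives 21900 nM and compound 2 (`O=C(Nc1ccc(NCC2CC2)cc1Cl)c1cc(Cl)ccc1O`) gives 14400 nM, values that lie within the scatter of each other. Compound 3 (`O=C(Nc1ccc(NCc2ccccc2)cc1Cl)c1cc(Cl)ccc1O`) has not yet been measured in this assay. Compared with compound 2, it has phenyl in place of cyclopropyl on a saturated chain carbon bound to a nitrogen on an aromatic ring. Among the compounds with values here, no step between measured compounds is available as a guide, so the expected change is small, within the scatter and if anything toward lower numbers: a 1.2-fold lower number from compound 2 to compound 3 (0.08 log units; within the scatter). The estimated value for compound 3 is 12000 nM, with an expected range from 5000 nM to 28000 nM.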

Compound 3, half-maximal cytotoxic concentration: 19700 nM
Compound 3: the middle estimate sits 1.6-fold (0.22 log units) below what was measured; the range from low to high includes it.
By their numbers in this assay, from the lowest: compounds 2, 3 and 1 (each within the scatter of the next).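

In this assay, within the data shown here, the change of cyclopropyl to phenyl on a saturated chain carbon bound to a nitrogen on an aromatic ring gives the first step at this position: a 1.4-fold higher number from compound 2 to compound 3 (0.14 log units; within the scatter). Cyclopropylmethyl and benzyl thus cannot be told apart on this read-out, even though the six-membered aromatic ring brings more heavy atoms than the three-membered ring it replaces. No measurement on these compounds offers an explanation for this result.

On these data alone, whether a benzyl group carrying a carboxylic acid or an amine would move the number beyond the scatter stays open.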